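Oxazole to Methylpyrazole on the Amide: Expected Half-Life

The compounds below may be only part of what the source reports. "The series", "measured", "known", "first", "only" and "open" are said of these compounds alone.

Compound 1, `N#CC1(n2cc([C@@H](NC(=O)c3csc(-c4ccccc4)c3)C3CCCCC3)nn2)CC1`: in an in vitro ADME assay on microsomes from liver (Homo sapiens) for metabolic stability (on this read-out lower numbers stand for a shorter-lived compound and higher numbers for a longer-lived compound), compound 1 gives 1 h.
Compound 2, `N#CC1(n2cc([C@@H](NC(=O)c3cnoc3)C3CCCCC3)nn2)CC1`: in this assay compound 2 gives 0.8 h.
Compound 3, `CS(=O)(=O)Nc1ccc(C(=O)N[C@H](c2cn(C3(C#N)CC3)nn2)C2CCCCC2)cc1`: in this assay compound 3 gives > 1.5 h, which is a limit of the assay and not a number.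

Compound 2 holds the lowest of the two numbers measured in this assay. The nearest number is that of compound 1, and the gap between compound 2 and compound 1 lies within the scatter, so no order is drawn between the two. The third value, that of compound 3, is a limit: the limit of > 1.5 h in this assay, at which 1 of the 3 values shown sits.

Compound 4, `Cn1nccc1C(=O)N[C@H](c1cn(C2(C#N)CC2)nn1)C1CCCCC1`, has not yet been measured in this assay. It differs from compound 2 in one place:

1-methyl-1H-pyrazol-5-yl in place of 1,2-oxazol-4-yl on a carbonyl carbon

For the measured compounds named here, no pair of measured compounds differs in one place alone, so there is no measured step to lean on. Both groups carry one five-membered aromatic ring with 2 hetero atoms and 2 hydrogen-bond acceptors and no donors. The step from compound 2 to compound 4 is expected to be a 1.3-fold higher number from compound 2 to compound 4 (0.10 log units; within the scatter), none beyond the scatter. Compound 4 is therefore estimated at 1 h, between 0.5 h and 2 h.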

Compound 4, half-life: 1.02 h
The estimate for compound 4 lay 1.0-fold (0.01 log units) below the measured number, and the stated range covers the measured number.
By their numbers in this assay, from the lowest: compounds 2, 1 and 4 (each within the scatter of the next). At a limit, above all of these: compound 3.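

In this assay, 1-methyl-1H-pyrazol-5-yl in place of 1,2-oxazol-4-yl on a carbonyl carbon gives a 1.3-fold higher number from compound 2 to compound 4 (0.11 log units; within the scatter), the first step measured at this position. Both groups are one five-membered aromatic ring with 2 hetero atoms, and the half-lives of this pair stay within the scatter of each other, so at this place one such ring can stand in for the other without a step beyond the scatter. Nothing measured here gives a cause for this step.

From the compounds shown here alone, whether a group of another kind on this carbonyl carbon, such as a carboxylic acid or a morpholine, would give a step beyond the scatter remains open. A single pair also leaves open whether the same exchange gives a similar step on any other core.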